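The source may hold more compounds than are shown below. What is called first, only, known or untested is meant among the compounds shown, and "the series" means these compounds.

In an assay on lysate for inhibition of 6-phosphofructo-2-kinase/fructose-2,6-bisphosphatase 3 (Homo sapiens), with stated times of 0.5 min and 45 min (on this read-out higher numbers stand for weaker inhibition and lower numbers for stronger inhibition), two compounds built on one shared core have been measured so far. Compound 1 `CN1CCCC(NS(=O)(=O)c2ccccc2Nc2cc(-c3ccc4ccn(C)c4c3)c3nccnc3c2)C1` gives 9780 nM, and compound 2 `CNC(=O)c1ccncc1Nc1cc(-c2ccc3ccn(C)c3c2)c2nccnc2c1` gives 7020 nM; these two values lie within the scatter of each other, so neither stands apart. Compound 3 `CC(=O)N1CCOC(CNC(=O)c2ccncc2Nc2cc(-c3ccc4ccn(C)c4c3)c3nccnc3c2)C1` has not yet been measured. It differs from compound 2 in one place: 4-acetylmorpholin-2-yl in place of hydrogen on a saturated chain carbon bound to an amide-type nitrogen. Going by the values given here, no measured step of this kind is available, so the change is expected to shift the number only a little, with the estimated step of a 1.4-fold lower number from compound 2 to compound 3 (0.15 log units; within the scatter) leaning slightly toward stronger inhibition but staying inside the scatter. Compound 3 is therefore expected to give about 5000 nM, within a range from 1500 nM to 15000 nM.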

Compound 3, half-maximal inhibitory concentration: > 100000 nM
Compound 3 was reported as a limit (the forecaster's own chance of this, stated with the estimate: 5%); middle value at least 20-fold (1.30 log units) from the limit.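

In this assay, placing 4-acetylmorpholin-2-yl on the saturated chain carbon bound to an amide-type nitrogen gives an at least 14-fold higher number from compound 2 to compound 3 (1.15 log units; beyond the scatter), so this position, unlike anything the first two compounds could show, responds strongly to what is attached there. The value of > 100000 nM for compound 3 is a limit of the assay and not a number, so the true size of the step stays unknown: the limit of > 100000 nM in this assay, at which 1 of the 3 values shown sits.

Going by these compounds, whether an ethyl chain at this place would keep inhibition remains open. Also open, on these data alone, is whether a morpholin-2-yl group without the acetyl would give the same loss.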